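The compounds below may be only part of what the source reports. "The series", "measured", "known", "first", "only" and "open" are said of these compounds alone.

Measured compounds:
- compound 2 `CC1CC/C(=N\Nc2ccc(F)cc2)c2ncc(C(=O)O)c(=O)n21` — 1200 nM in a functional assay (mast cells) for inhibition, with Rattus norvegicus as the target; on this read-out lower numbers stand for an effect already at smaller amounts and higher numbers for an effect only at larger amounts of compound
- compound 3 `CC1CC/C(=N\Nc2cccc(Cl)c2)c2ncc(C(=O)O)c(=O)n21` — 311000 nM in this assay
- compound 1 `CCOC(=O)c1cnc2n(c1=O)C(C)CC/C2=N\Nc1cccc(C(=O)O)c1` — 740000 nM in this assay

Compound 2 stands lowest of the three numbers in this assay; compound 3 sits a 260-fold higher number from compound 2 to compound 3 (2.41 log units; beyond the scatter) away, and compound 1 further still. Both departures from the shared core of compound 2 that have been measured end at much higher numbers.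

The next compound is compound 4 `CC1CC/C(=N\Nc2ccc(CC(=O)O)cc2)c2ncc(C(=O)O)c(=O)n21`, not yet measured in this assay. It differs from compound 2 at the aryl ring: carboxymethyl in place of fluoro on an aromatic carbon.

Among the compounds with values here, only one measured step bears on it directly: a 260-fold higher number from compound 2 to compound 3 (2.41 log units; beyond the scatter), where the aryl substituent was exchanged and the number rose steeply. Compound 1, which also carries a carboxylic acid on the aryl ring, though with other changes to the core, gives 740000 nM, again far above compound 2. Both comparisons point the same way: the aryl ring in compound 2 seems to sit at a favourable point, and altering it has so far cost a great deal.

A large rise in this assay is therefore expected for compound 4, of about an 83-fold higher number from compound 2 to compound 4 (1.92 log units; beyond the scatter). Compound 4 is estimated at 100000 nM, with a plausible range from 10000 nM to 700000 nM.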

Compound 4, half-maximal effective concentration: 3400 nM
Compound 4: middle estimate off by 29-fold (1.47 log units), on the high side; the measured number lies below the stated range.
By their numbers in this assay, from the lowest: compound 2; then compound 4; then compound 3; then compound 1.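

In this assay, carboxymethyl in place of fluoro on an aromatic carbon, para to a large group, gives a 2.8-fold higher number from compound 2 to compound 4 (0.45 log units; beyond the scatter), a modest step, though one beyond the scatter. The position therefore accepts a substituent with more heavy atoms, a hydrogen-bond donor and a hydrogen-bond acceptor at far less cost than a 260-fold higher number from compound 2 to compound 3 (2.41 log units; beyond the scatter) step would have suggested, so changing the aryl substituent of compound 2 does not in itself bring a large rise. No measurement on these compounds accounts for the gap between the two steps.

The compounds shown leave open whether the acid function of the carboxymethyl group matters at this position: a methyl ester or an amide in its place, or a longer chain ending in a carboxylic acid, would separate the end group from the chain. A chloro group para to a large group, set against compound 2 and compound 3, would show whether the steep rise goes with the chlorine or with its place on the ring.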